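This account rests on a few compounds, and the source may have more. Where it says the series, first, only, none or still open, it means among the compounds named here.

Of the compounds shown here, three have so far been measured in a physicochemical assay for solubility, read by HPLC, using the shake flask method, measured as kinetic solubility, with a stated time of 2 h, at pH 7.4; on this read-out higher numbers stand for higher solubility and lower numbers for lower solubility. Compound 1 `Cc1cc(NCc2cccnc2)n2nc(C)c(-c3ccccc3)c2n1` gives 110000 nM. Compound 3 `Cc1cc(NCc2nccn2C)n2nc(C)cc2n1` gives 182000 nM. Compound 2 `Cc1cc(NCc2ccccn2)n2ncc(-c3cccc(F)c3)c2n1` gives 5000 nM, the lowest of the three numbers; the nearest is compound 1 and the furthest is compound 3, and both lie higher by margins beyond the usual scatter of this assay. Going by the values given here, no two of the measured compounds differ in a single place, so no measured pair shows directly what a change at one position does.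

The next compound is compound 4 `Cc1cc(NCc2ccccn2)n2ncc(-c3cccc(N(C)C)c3)c2n1`, which differs from compound 2 only as follows: dimethylamino in place of fluoro on an aromatic carbon. Among the compounds with values here, since no measured pair shows this change, the expectation rests on where compound 2 stands and the stated difference alone. The step from compound 2 to compound 4 is expected to be a moderate rise, a 3.0-fold higher number from compound 2 to compound 4 (0.48 log units; beyond the scatter). In this assay compound 4 is therefore estimated at 15000 nM, within a range from 4000 nM to 60000 nM.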

Compound 4, solubility: 94600 nM
Compound 4: the middle estimate sits 6.3-fold (0.80 log units) below what was measured, and the stated range ends below it.
By their numbers in this assay, from the lowest: compound 2; then compounds 4, 1 and 3 (each within the scatter of the next).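

In this assay, going by these compounds alone, putting dimethylamino in place of fluoro gives a 19-fold higher number from compound 2 to compound 4 (1.28 log units; beyond the scatter) and is the only comparison here that isolates a single change. It shows that this position on the outer aromatic ring is far from indifferent: going from 3-fluorophenyl to 3-(dimethylamino)phenyl, with the rest of the molecule held constant, is enough to produce a large step on this read-out. Nothing available explains why the number moves this much.

Going by these compounds, this single step cannot separate the loss of fluoro from the arrival of dimethylamino, so it remains open whether a plain hydrogen, a methoxy group or a morpholine ring at this position would give a similar rise. On these data alone, it also remains open whether the same exchange would have a similar effect on the other compounds, which carry different side chains.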